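A few compounds are considered here, and "the series" means these few. Any claim that something is new, unique, unknown or untested is made for them only; others in the source may bear on it.

Working notes on the series.

In a functional assay on DLD-1 cells (Homo sapiens) for antiproliferative activity, read by CellTiter-Glo, with a stated time of 72 h (on this read-out lower numbers stand for stronger inhibition and higher numbers for weaker inhibition), compound 1 `COc1ccccc1-c1cccc(S(=O)(=O)N2CCC(N3CCC(C)CC3)CC2)c1` gives 21 nM. Compound 3 `Cc1c(C)c(S(=O)(=O)N2CCC(N3CCC(C)CC3)CC2)c(C)c2c1OC(C)(C)C2` gives 1.2 nM in this assay, a lower number than compound 1, and the gap lies beyond the usual scatter; of the two numbers shown, compound 1 stands the higher. Compound 2 `Cc1cc(C)c(S(=O)(=O)N2CCC(C3OCC(C)CO3)CC2)c(C)c1` reaches only a limit in this assay, > 5000 nM, which is a limit of the assay and not a number; it accounts for (the limit of > 5000 nM in this assay, at which 1 of the 3 values shown sits).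

Compound 4 `Cc1cc(C)cc(-c2cccc(S(=O)(=O)N3CCC(N4CCC(C)CC4)CC3)c2)c1` has not yet been measured in this assay. It differs from compound 1 in one place: 3,5-dimethylphenyl in place of 2-methoxyphenyl on an aromatic carbon. Among the measured compounds shown here, no measured pair in the set shows this change on its own, so the size of the step is open. The 2-methoxyphenyl gives way to a 3,5-dimethylphenyl at the same aromatic carbon, and the rest of the shared core is kept. For compound 4 the expectation is a step of a 1.2-fold higher number from compound 1 to compound 4 (0.08 log units; within the scatter), with no strong direction beyond the scatter. Compound 4 is estimated at 25 nM, within a range of 8 nM to 80 nM.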

Compound 4, half-maximal inhibitory concentration: 41 nM
Compound 4: middle estimate off by 1.6-fold (0.21 log units), on the low side; the measured number falls inside the stated range.
By their numbers in this assay, from the lowest: compound 3; then compounds 1 and 4 (each within the scatter of the next). At a limit, above all of these: compound 2.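

Placing 3,5-dimethylphenyl where 2-methoxyphenyl stood gives a 2.0-fold higher number from compound 1 to compound 4 (0.29 log units; within the scatter) in this assay, the first single-place comparison in the series. For this pair, the aromatic carbon meta to a large group takes either aryl group with no step beyond the scatter, even though the hydrogen-bond acceptor of the 2-methoxyphenyl is lost and the heavy-atom count stays the same. No measurement at hand bears on the reason for this result.

Going by these compounds, both groups at this carbon are six-membered aromatic rings of carbon only, so the response to a different kind of group, such as a carboxylic acid, an amine or a longer chain, remains open. A 3,5-dimethoxyphenyl group would show whether the oxygen and the methyl groups can be read apart.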